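Shortening the Tetrazole Chain on a Shared Core

This account rests on a few compounds, and the source may have more. Where it says the series, first, only, none or still open, it means among the compounds named here.

Compound 1 `CC1=C(CCc2nnn[nH]2)c2ccccc2/C1=C\c1ccc(C(C)(C)C)cc1` and compound 3 `CC1=C(Cc2nnn[nH]2)c2ccccc2/C1=C\c1ccc(C(C)(C)C)cc1` share one core and differ only in that (1H-tetrazol-5-yl in place of (1H-tetrazol-5-yl)methyl on a saturated chain carbon bound to a double-bonded ring carbon). In a functional assay on MDA-MB-231 cells (Homo sapiens) for inhibition, read by MTT assay, with a stated time of 48 h (on this read-out lower numbers stand for stronger inhibition and higher numbers for weaker inhibition), compound 1 gives 12500 nM, and compound 3 gives 14300 nM; the step of a 1.1-fold higher number from compound 1 to compound 3 (0.06 log units; within the scatter). Compound 2 `CC1=C(CCc2nnn[nH]2)c2ccccc2/C1=C\c1ccccc1C(F)(F)F` has no reported result: in this assay compound 2 gives "not determined" (no result reported). The difference between the core of compound 2 and the core of compound 1 is not broken down here. Compound 4 `CC1=C(Cc2nnn[nH]2)c2ccccc2/C1=C\c1ccccc1C(F)(F)F` is related to compound 2 by the same kind of change: 1H-tetrazol-5-yl in place of (1H-tetrazol-5-yl)methyl on a saturated chain carbon bound to a double-bonded ring carbon. Since compound 2 gives no number, the expectation for compound 4 rests on compound 3, which gives 14300 nM with the same shorter chain. Compound 4 is expected to give about 14000 nM in this assay, with a range from 5000 nM to 40000 nM.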

Compound 4, half-maximal inhibitory concentration: 40800 nM
Beside the measured number, compound 4's estimate is 2.9-fold (0.46 log units) below it; measured number above the stated range.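

In this assay, among these compounds, compound 2 has no reported result, and no step to compound 4 can be read from it. The compounds shown leave open whether shortening the chain shifts the number on the core of compound 4, and no evidence on the cause of this result is available.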